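Dropping one bromine from a dibromocoumarin thiazole

The compounds below may be only part of what the source reports. "The series", "measured", "known", "first", "only" and "open" are said of these compounds alone.

Of the compounds shown here, two have been tested in a functional assay on the whole organism for inhibition, with Rattus norvegicus as the target, read by paw edema, in the formalin test, with a stated time of 24 h, at a dose of 100 mg/kg by the intraperitoneal route; a lower number here means less inhibition, a higher number more inhibition at the dose given (going by the name of the read-out). Compound 1, with the structure `O=c1cc(CNc2nc(-c3cc4cc(Br)cc(Br)c4oc3=O)cs2)c2cc(Cl)ccc2[nH]1`, gives 9.35% in this assay. Compound 2, with the structure `Cc1cccc2c(CNc3nc(-c4cc5cc(Br)ccc5oc4=O)cs3)cc(=O)[nH]c12`, gives 16.9% in this assay. For the measured compounds named here, these two compounds differ from each other in more than one place, so no single step can be drawn between them; all that can be said is that their two numbers lie within the usual scatter of each other, so that the inhibition in this assay is level between the pair.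

Compound 3, with the structure `O=c1cc(CNc2nc(-c3cc4cc(Br)ccc4oc3=O)cs2)c2cc(Cl)ccc2[nH]1`, has not yet been measured. It differs from compound 1 in one place: hydrogen in place of bromo on an aromatic carbon. Going by the values given here, no step between measured compounds tells how such a change plays out here. Given how close the two measured numbers sit, the expectation is that this change moves the read-out little, if at all, beyond the scatter, so that the step from compound 1 to compound 3 is estimated at a number 2.7 percentage points higher from compound 1 to compound 3 (within the scatter). Compound 3 is accordingly expected to give about 12% in this assay, within a range from 3% to 25%.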

Compound 3, a percentage reported as inhibition, in the whole organism at one dose (the size of the read-out at that dose, not a potency): 9.08%
Beside the measured number, compound 3's estimate is 2.9 percentage points above it, within the range that was stated.
By their numbers in this assay, from the lowest: compounds 3, 1 and 2 (each within the scatter of the next).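

For the compounds shown here, the first step in one place now stands: hydrogen in place of bromo, on the aromatic carbon ortho to a fused ring and meta to a bromo group, comes with a number 0.3 percentage points lower from compound 1 to compound 3 (within the scatter) in this assay. At this position, then, the bromo group, a single heavy atom, can give way to hydrogen without moving the read-out beyond the usual scatter, and this holds for the size of the inhibition at the one dose used, not for potency. No measurement at hand offers an explanation for this result.

The compounds shown carry only bromo or hydrogen at this position, so it remains open whether a different group there, such as a methoxy group, an amine or a carboxylic acid, would leave the inhibition as level as this change did. Going by these compounds, it also remains open what a change to the other bromo group, which all three compounds share, would do to the read-out.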